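Swapping Furan Isomers: From Compound 2 to Compound 3

The source may report more compounds than this note shows. Statements on the series, on what has been measured and on what is new or still open speak of the compounds shown alone.

Two compounds have been measured in an assay on membranes from HeLa cells for displacement of a labelled ligand from adenosine receptor A3 (Homo sapiens), read by scintillation counting, with a stated time of 180 min, tested at 1 uM; on this read-out lower numbers stand for less inhibition and higher numbers for more inhibition at the one concentration tested (going by the name of the read-out):
compound 1, `COC(=O)C1=C(C)NC(=O)NC1c1ccoc1`, gives 2%
compound 2, `COC(=O)C1=C(C)N(C)C(=O)NC1c1ccco1`, gives 9%

Compound 2 holds the higher of these two numbers, yet compound 1 sits only a small distance beneath it, and that gap lies within the scatter of repeated runs, so the two cannot be told apart. For the measured compounds named here, no step between compounds differing in a single place is available to guide the next comparison. Compound 3, `COC(=O)C1=C(C)N(C)C(=O)NC1c1ccoc1`, is the next to be tested in this assay. The change from compound 2 to compound 3 is furan-3-yl in place of furan-2-yl on a saturated ring carbon. Since compound 1 already carries furan-3-yl and gives 2%, the step from compound 2 to compound 3 is expected to be small, if anything slightly downward, and not beyond the scatter: an estimated a number 4 percentage points lower from compound 2 to compound 3 (within the scatter). Compound 3 is therefore expected to show about 5%, plausibly between 0% and 15%.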

Compound 3, a percentage reported as inhibition, at one concentration (the size of the read-out at that concentration, not a potency): 7%
Compound 3: middle estimate off by 2 percentage points, on the low side; the measured number falls inside the stated range.
By their numbers in this assay, from the lowest: compounds 1, 3 and 2 (each within the scatter of the next).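

In this assay, furan-3-yl in place of furan-2-yl on the saturated ring carbon gives a number 2 percentage points lower from compound 2 to compound 3 (within the scatter) and so the two furan isomers cannot be told apart at this position. The compounds now also offer a comparison at a second place: methyl in place of hydrogen on the amide-type nitrogen in the ring gives a number 5 percentage points higher from compound 1 to compound 3 (within the scatter) and that change cannot be told apart from no change either. Nothing available bears on why these numbers stay so close together.

On these data alone, it remains open whether any group on this saturated ring carbon, or on that ring nitrogen, can move the read-out beyond the scatter. A phenyl ring, an amine or a carboxylic acid in place of the furan, or a longer chain such as ethyl in place of the methyl on the nitrogen, would address this.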